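Dichlorophenyl for Fluorophenyl on a Shared Core

The compounds below may be only part of what the source reports. "The series", "measured", "known", "first", "only" and "open" are said of these compounds alone.

Compound 1, `C=CC1=C(C(=O)NCCC)C(c2ccc(Cl)c(Cl)c2)OC1`: > 100000 nM
Compound 2, `C=CC1=C(C(=O)NCc2ccccc2)C(c2ccc(F)cc2)OC1`: > 100000 nM

Both values come from a functional assay on HeLa cells (Homo sapiens) for cytotoxicity, read by MTT assay, with a stated time of 24 h; on this read-out lower numbers stand for stronger inhibition and higher numbers for weaker inhibition. In this assay compound 2 reaches only a limit of the assay, > 100000 nM, not a number. Compound 1 likewise sits at a limit, > 100000 nM. The whole picture so far is the limit of > 100000 nM in this assay, at which 2 of the 2 values shown sit. Compound 3, `C=CC1=C(C(=O)NCc2ccccc2)C(c2ccc(Cl)c(Cl)c2)OC1`, differs from compound 2 by 3,4-dichlorophenyl in place of 4-fluorophenyl on a saturated ring carbon. Within the data shown here, no step between measured compounds exists, so only this standing at the limit guides the outlook. Compound 3 is therefore expected to remain at the limit, and the expected step that the limit leaves unreadable from compound 2 to compound 3 is none beyond the scatter. For compound 3 the estimate is 150000 nM, with a range from 40000 nM to 600000 nM.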

Compound 3, half-maximal inhibitory concentration: > 100000 nM
Compound 3 gave a limit, no number; the forecaster's own chance of this, stated with the estimate: 85%; the middle value lies beyond the limit too.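

Among these compounds, compound 3, like compound 1 and compound 2, gives no number, so no step between them can be read: the limit of > 100000 nM in this assay, at which 3 of the 3 values shown sit. The compounds shown leave open whether swapping 4-fluorophenyl for 3,4-dichlorophenyl, or ethyl for phenyl, changes anything in this assay at all.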